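This account rests on a few compounds, and the source may have more. Where it says the series, first, only, none or still open, it means among the compounds named here.

Compound 3, whose structure is `Cc1cc(OCc2nnc(SCc3ccc(Cl)cc3Cl)o2)cc2oc(=O)cc(C)c12`, was tested in a functional assay on MDA-MB-231 cells (Homo sapiens) for antiproliferative activity, read by MTT assay, with a stated time of 24 h; on this read-out higher numbers stand for weaker inhibition and lower numbers for stronger inhibition. In this assay compound 3 gives > 100000 nM, which is a limit of the assay rather than a number. Two related compounds were measured in the same way. Compound 1 has the structure `CCSc1nnc(COc2cc(C)c3c(C)cc(=O)oc3c2)o1`, and in this assay compound 1 gives > 100000 nM, again a limit. Compound 2 has the structure `CCCCSc1nnc(COc2cc(C)c3c(C)cc(=O)oc3c2)o1`, and in this assay compound 2 gives > 100000 nM, also a limit. All three values thus sit together, as summed up in the limit of > 100000 nM in this assay, at which 3 of the 3 values shown sit, and compound 3 stands nowhere apart from the other two. The steps among them cannot be read: the step that the two limits leave unreadable from compound 1 to compound 2, the step that the two limits leave unreadable from compound 1 to compound 3 and the step that the two limits leave unreadable from compound 2 to compound 3 each join two limits. Compound 4, with the structure `CCCS(=O)(=O)c1nnc(COc2cc(C)c3c(C)cc(=O)oc3c2)o1`, is still to be measured. It differs from compound 3 by propylsulfonyl in place of (2,4-dichlorobenzyl)sulfanyl on an aromatic carbon. Among the measured compounds shown here, none of the measured steps gives a readable size for a change at this position, so neither a direction nor a size can be drawn from them for this assay. The expectation for compound 4 is that it stays at the limit, with an estimated value of 150000 nM and a range from 30000 nM to 1000000 nM. That estimate corresponds to an expected step that the limit leaves unreadable from compound 3 to compound 4.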

Compound 4, half-maximal inhibitory concentration: 7070 nM
For compound 4 the middle estimate is 21-fold (1.33 log units) above the measured one; measured number below the stated range.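

Steps among compound 1, compound 2 and compound 3 cannot be read, so the earlier compounds could not show whether a change at this carbon of the five-membered aromatic ring affects the read-out at all. In this assay, the new result shows that it can: replacing the group on that carbon with propylsulfonyl gives an at least 14-fold lower number from compound 3 to compound 4 (1.15 log units; beyond the scatter) when (2,4-dichlorobenzyl)sulfanyl leaves, an at least 14-fold lower number from compound 2 to compound 4 (1.15 log units; beyond the scatter) when butylsulfanyl leaves and an at least 14-fold lower number from compound 1 to compound 4 (1.15 log units; beyond the scatter) when ethylsulfanyl leaves. Among these four compounds, the three sulfanyl groups, whether a short chain, a longer chain or one carrying a ring, share one limit, and only the propylsulfonyl compound gives a number, so no compound shown goes against this split: the limit of > 100000 nM in this assay, at which 3 of the 4 values shown sit.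

The compounds shown do not separate the effect of the two oxygens on the sulfur from that of the chain, for propylsulfonyl is the only sulfonyl group among them and no propylsulfanyl partner stands beside it. From the compounds shown here alone, how butylsulfonyl, a longer chain on the sulfonyl or an amine in this place would read also stays open.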